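The source may hold more compounds than are shown below. What is called first, only, known or untested is meant among the compounds shown, and "the series" means these compounds.

Measured in a functional assay (strain AB) with Danio rerio as the target, read by microscopy, with a stated time of 1 h; a lower number here means that less compound is needed, a higher number that more compound is needed for the effect:
- compound 1 `CC(C)(C)CN1CCc2c(sc(NC(=O)Nc3ccc(Cl)cc3)c2C(N)=O)C1`: 5560 nM
- compound 2 `COCCCN1CCc2c(sc(NC(=O)Nc3ccc(Cl)cc3)c2C(N)=O)C1`: 2400 nM

Of these two compounds, compound 2 has the lower number, and the gap to compound 1 lies beyond the scatter. Compound 3 `CC(C)CN1CCc2c(sc(NC(=O)Nc3ccc(Cl)cc3)c2C(N)=O)C1`, not yet measured, has isopropyl in place of 2-methoxyethyl on a saturated chain carbon bound to an amine nitrogen in a ring.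

Among the measured compounds shown here, only one measured step bears on this change: a 2.3-fold lower number from compound 1 to compound 2 (0.36 log units; beyond the scatter). That modest step replaced tert-butyl with 2-methoxyethyl at the same place. Compound 3 returns to an all-carbon group, as in compound 1, so a step of similar or smaller size is expected in the opposite direction in this assay, towards a higher number. One step is thin evidence, so the range is kept wide. The expected step is a 1.7-fold higher number from compound 2 to compound 3 (0.22 log units; within the scatter). Compound 3 is estimated at 4000 nM, with a range of 1800 nM to 8500 nM.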

Compound 3, half-maximal effective concentration: 4510 nM
Estimate against measurement, compound 3: 1.1-fold (0.05 log units) below, within the range that was stated.
By their numbers in this assay, from the lowest: compounds 2, 3 and 1 (each within the scatter of the next, the first and the last beyond it).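

In this assay, the step of a 1.9-fold higher number from compound 2 to compound 3 (0.27 log units; within the scatter) stays within the scatter, so on a saturated chain carbon bound to an amine nitrogen in a ring, isopropyl cannot be told apart from 2-methoxyethyl. The second new step, a 1.2-fold lower number from compound 1 to compound 3 (0.09 log units; within the scatter), is also within the scatter, so hydrogen in place of methyl gives no readable difference here, and compound 3 lies within the scatter of both compound 1 and compound 2, although those two are beyond it from each other. Nothing at hand gives a cause for these numbers. The compounds shown leave open whether an amine, a carboxylic acid or a longer chain at this place would separate clearly from compound 2. They also leave open whether these small steps would hold with another group in place of the chlorine on the shared core.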